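Replacing bromo with methoxy in compound 3

The source may report more compounds than this note shows. Statements on the series, on what has been measured and on what is new or still open speak of the compounds shown alone.

Measured in a functional assay on K562 cells (Homo sapiens) for antiproliferative activity, read by sulforhodamine B assay, with a stated time of 48 h; a higher number here means a weaker inhibitor, a lower number a stronger inhibitor:
- compound 1 `O=C1NCCN1c1ccc(S(=O)(=O)Nc2ccc3[nH]ccc3c2)cc1`: 340 nM
- compound 2 `Cc1cccc(NS(=O)(=O)c2ccc(N3CCNC3=O)cc2)c1`: 200 nM
- compound 3 `O=C1NCCN1c1ccc(S(=O)(=O)Nc2cccc(Br)c2)cc1`: 87 nM

Compound 3 has the lowest number of the three, and its gaps to compound 2 and to compound 1 both lie beyond the usual scatter. The next compound, compound 4 `COc1cccc(NS(=O)(=O)c2ccc(N3CCNC3=O)cc2)c1`, changes one group of compound 3: methoxy in place of bromo on an aromatic carbon. Methoxy takes the place of bromo on an aromatic carbon, meta to a large group.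

Within the data shown here, no measured compound carries methoxy, so the effect of this change is unknown. Among the measured compounds shown here, the only measured step that bears on it is a 2.3-fold lower number from compound 2 to compound 3 (0.36 log units; beyond the scatter), a modest change in which bromo replaced methyl. On that evidence, removing bromo is expected to raise the number in this assay by a similarly modest amount, not to lower it.

The expected step is a 2.0-fold higher number from compound 3 to compound 4 (0.29 log units; within the scatter). Compound 4 is estimated at 170 nM, with an expected range of 70 nM to 400 nM.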

Compound 4, half-maximal inhibitory concentration: 230 nM
For compound 4 the middle estimate is 1.4-fold (0.13 log units) below the measured one, and the stated range covers the measured number.
By their numbers in this assay, from the lowest: compound 3; then compounds 2, 4 and 1 (each within the scatter of the next).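

In this assay, bromo now has the lowest number against two other groups at this place: methoxy gives a 2.6-fold higher number from compound 3 to compound 4 (0.42 log units; beyond the scatter) and methyl, on going to bromo, gives a 2.3-fold lower number from compound 2 to compound 3 (0.36 log units; beyond the scatter) in the other direction. The step of a 1.2-fold higher number from compound 2 to compound 4 (0.06 log units; within the scatter) shows that methoxy and methyl cannot be told apart at this place, so the gain so far belongs to bromo alone. Nothing available explains what sets bromo apart from these two groups.

On these data alone, whether that gain is special to bromo or shared by other groups, such as chloro or trifluoromethyl, remains open. Also open, as far as these compounds go, is how an amine or a carboxylic acid would fare here, and whether any of these groups would give a number near that of compound 3.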